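Cytotoxicity at the top concentration: a benzyloxy analogue

The compounds below may be only part of what the source reports. "The series", "measured", "known", "first", "only" and "open" are said of these compounds alone.

Measured compounds in an ADME assay on Raji cells (Homo sapiens) for cytotoxicity, read by CellTiter-Glo and resazurin assay, with a stated time of 72 h; on this read-out lower numbers stand for an effect already at smaller amounts and higher numbers for an effect only at larger amounts of compound:
Compound 1 `CCOC(=O)CCCCCOc1cccc(CN(C(=O)c2ccc(-c3cccc(NC(C)=O)c3)cc2)C(C)C)c1` gives > 26000 nM, which is a limit of the assay.
Compound 2 `CCOC(=O)CCCCCOc1cccc(CN(C(=O)c2ccc(-c3cccc(C(C)=O)c3)cc2)C(C)C)c1` gives > 26000 nM, again a limit.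
Compound 3 `CCOC(=O)CCCCCOc1cccc(CN(C(=O)c2ccc(-c3cccc(OC(C)C)c3)cc2)C(C)C)c1` gives > 26000 nM, also a limit.

Compound 3 therefore stands where every measured compound stands, at the limit, as summarised by the limit of > 26000 nM in this assay, at which 3 of the 3 values shown sit. For the measured compounds named here, the only measured steps are unreadable for that reason: a step that the two limits leave unreadable from compound 1 to compound 2, a step that the two limits leave unreadable from compound 1 to compound 3 and a step that the two limits leave unreadable from compound 2 to compound 3. None of the three changes on the terminal aromatic ring produced a measurable value, so nothing here separates acetamido, acetyl and isopropoxy.

Compound 4 `CCOC(=O)CCCCCOc1cccc(CN(C(=O)c2ccc(-c3cccc(OCc4ccccc4)c3)cc2)C(C)C)c1` differs from compound 3 by benzyl in place of isopropyl on an oxygen on an aromatic ring. Going by the values given here, the three unreadable steps bear on this change only in that exchanges at this position of the shared core have so far left the read-out at its limit; no step of measurable size is expected, and a step that the limit leaves unreadable from compound 3 to compound 4 is therefore estimated to be none beyond the scatter. Compound 4 is expected to give 40000 nM in this assay, within 15000 nM to 120000 nM, most likely again reported only as a limit.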

Compound 4, half-maximal effective concentration: > 26000 nM
Compound 4 ended at the assay's limit (the forecaster's own chance of this, stated with the estimate: 80%); the middle value does not contradict the limit.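

Compound 4 gives > 26000 nM in this assay, which is again a limit. Its steps from compound 1, compound 2 and compound 3 therefore cannot be read: the limit of > 26000 nM in this assay, at which 4 of the 4 values shown sit.

The compounds shown leave open whether acetamido, acetyl, isopropoxy and benzyloxy differ at all in this assay.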